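Cytotoxicity in the series: pyrrolyl replaced by a fused bicycle

This account rests on a few compounds, and the source may have more. Where it says the series, first, only, none or still open, it means among the compounds named here.

Measured so far:
compound 1 `Cc1cc(-c2ccc3[nH]ccc3c2)cn2c(CSCCc3ccccc3)cnc12` — >= 20 ug/mL
compound 2 `Cc1cc(-n2cccc2)cn2c(CSCCc3ccccc3)cnc12` — >= 4 ug/mL

In an ADME assay on HEL cells (Homo sapiens) for cytotoxicity, with a stated time of 3 days (a lower number here means that less compound is tolerated, a higher number that more compound is tolerated), compound 1 gives >= 20 ug/mL, which is a limit of the assay and not a number. Compound 2 gives in this assay >= 4 ug/mL, again a limit. Going by the values given here, the one measured step, a step that the two limits leave unreadable from compound 1 to compound 2, is therefore unreadable: both of its ends sit at limits (the limit of >= 20 ug/mL in this assay, at which 1 of the 2 values shown sits, (the limit of >= 4 ug/mL in this assay, at which 1 of the 2 values shown sits)). Where compound 2 stands is thus known only as a limit, and the single other value shown is a limit as well.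

Compound 3 `Cc1cc(-n2ccc3cccnc32)cn2c(CSCCc3ccccc3)cnc12` has not yet been measured. It differs from compound 2 by a group of 9 heavy atoms (7 carbon, 2 nitrogen; one five-membered aromatic ring with 1 hetero atom, one six-membered aromatic ring with 1 hetero atom) in place of a group of 5 heavy atoms (4 carbon, 1 nitrogen; one five-membered aromatic ring with 1 hetero atom), on an aromatic carbon. Among the compounds with values here, the only measured step that touches this position is the unreadable one, so no size and no direction of step in this assay can be drawn from the data; the entering group does bring a fused two-ring system onto the aromatic carbon, as compound 1 carries one, but the two limits do not tell how that played out. For compound 3 the expected value is 20 ug/mL, with a range of 4 ug/mL to 100 ug/mL. The step this estimate means, a step that the limit leaves unreadable from compound 2 to compound 3, is expected to end once more at a limit rather than a number.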

Compound 3, minimum cytotoxic concentration: 20 ug/mL
For compound 3 middle estimate and measured number coincide at the digits printed; low and high end bracket the measured number.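

In this assay, going by these compounds alone, compound 3 gives 20 ug/mL, the first value at this position that is not a limit, so a group with a five-membered and a six-membered aromatic ring, each with a hetero atom, now has a plain number on this aromatic carbon. Against compound 1, which carries 1H-indol-5-yl at the same place and whose value is a limit, the exchange of a ring carbon for a nitrogen gives a number no higher from compound 1 to compound 3 (the limit leaves the size open), so only a direction is fixed and the true distance stays unknown. The value of compound 2 is also a limit, and the step from it to compound 3 cannot be read: the limit of >= 4 ug/mL in this assay, at which 1 of the 3 values shown sits.

On these data alone, with only compound 3 carrying a number, it remains open whether the value in this assay responds to the group on this aromatic carbon at all, or how far 1H-pyrrol-1-yl and 1H-indol-5-yl truly lie from the group of compound 3. An amine, a carboxylic acid or a longer chain on this carbon would test the position with groups outside the aromatic rings seen here.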